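The source may hold more compounds than are shown below. What is called first, only, known or untested is meant among the compounds shown, and "the series" means these compounds.

Compound 1 `CC(=O)N1N=C(c2cccc3ccccc23)CC1c1cccc(Cl)c1Cl` gives 19100 nM in a functional assay on OVCAR cells (Homo sapiens) for cytotoxicity, read by sulforhodamine B assay, with a stated time of 48 h; a higher number here means a weaker inhibitor, a lower number a stronger inhibitor.
Compound 2 `CC(=O)N1N=C(c2cccc3ccccc23)CC1c1ccc2ccccc2c1` gives 250 nM.
Compound 3 `O=CCN1N=C(c2ccc3ccccc3c2)CC1c1ccccc1` gives 21500 nM.

Compound 3 and compound 1 sit within the scatter of each other, while compound 2 gives a far lower number than compound 3, so compound 3 lies at the weak end of what has been measured. Compound 4 `O=CCN1N=C(c2ccc3ccccc3c2)CC1/C=C/c1ccccc1` differs from compound 3 by 2-phenylethenyl in place of phenyl on a saturated ring carbon. Among the measured compounds shown here, no measured pair shows this kind of change, so there is nothing to read a step from. Compound 4 is expected to give 15000 nM in this assay, within the range 4000 nM to 60000 nM. The expected step is therefore a 1.4-fold lower number from compound 3 to compound 4 (0.16 log units; within the scatter), which is not expected to exceed the scatter in either direction.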

Compound 4, half-maximal inhibitory concentration: 18100 nM
Compound 4: the middle estimate sits 1.2-fold (0.08 log units) below what was measured; the range from low to high includes it.
By their numbers in this assay, from the lowest: compound 2; then compounds 4, 1 and 3 (each within the scatter of the next).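

In this assay, putting 2-phenylethenyl in place of phenyl on the saturated ring carbon gives a 1.2-fold lower number from compound 3 to compound 4 (0.07 log units; within the scatter) as its step. Among the compounds shown here, this is the first reading at this position, and it shows that the larger group, with its double bond outside aromatic rings, does not separate the two compounds beyond the scatter. Nothing available explains this result. Going by these compounds, whether an amine, a carboxylic acid or a longer chain at this ring carbon would give a step beyond the scatter remains open.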